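The source may hold more compounds than are shown below. What is called first, only, known or untested is meant among the compounds shown, and "the series" means these compounds.

Measured in a physicochemical assay for lipophilicity, read by HPLC, at pH 7.4; a lower number here means a more polar compound, a higher number a more lipophilic compound:
- compound 1 `Cc1cc(OCCCS(C)(=O)=O)c(Cl)c(C)c1-c1cccc(COc2ccc3c(c2)OC[C@H]3CC(=O)O)c1`: 3.07
- compound 2 `Cc1cc(OCCCN2CCCC2=O)cc(C)c1-c1cccc(COc2ccc3c(c2)OC[C@H]3CC(=O)O)c1`: 3.22

Compound 2, at 3.22, lies within the usual scatter of repeated measurements of compound 1, at 3.07, so the two cannot be told apart on these numbers.

Compound 3 `Cc1cc(OCC2(O)CCS(=O)(=O)CC2)cc(C)c1-c1cccc(COc2ccc3c(c2)OC[C@H]3CC(=O)O)c1` keeps the rest of compound 2 and differs in one place: 4-hydroxy-1,1-dioxothian-4-yl in place of 2-(2-oxopyrrolidin-1-yl)ethyl on a saturated chain carbon bound to an oxygen on an aromatic ring. In words, 4-hydroxy-1,1-dioxothian-4-yl stands in place of 2-(2-oxopyrrolidin-1-yl)ethyl on a saturated chain carbon bound to an oxygen on an aromatic ring.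

For the measured compounds named here, no two measured compounds differ in just one place, so no measured step can guide the size of this one. The expectation therefore rests on the structural change alone. The entering group counts more hydrogen-bond donors and acceptors than the leaving one, so from compound 2 at 3.22 a fall in this assay beyond the scatter is expected. The estimated change is a number 0.82 log units lower from compound 2 to compound 3 (beyond the scatter). For compound 3 the expected value is 2.4, with an estimated range from 2 to 2.8.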

Compound 3, distribution coefficient: 2.43
Beside the measured number, compound 3's estimate is 0.03 log units below it, within the range that was stated.
By their numbers in this assay, from the lowest: compound 3; then compounds 1 and 2 (each within the scatter of the next).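

For the compounds shown here, compound 2 and compound 3 give the first step that can be read at this place, on a saturated chain carbon bound to an oxygen on an aromatic ring, since compound 1 and compound 2 differ in more than one place. In this assay, putting 4-hydroxy-1,1-dioxothian-4-yl in place of 2-(2-oxopyrrolidin-1-yl)ethyl gives a number 0.79 log units lower from compound 2 to compound 3 (beyond the scatter), so with the rest of the structure unchanged, this one substitution moves the number by more than repeat measurements would. The entering group has 1 hydrogen-bond donor and 3 hydrogen-bond acceptors against 0 and 1 for the group it replaces, but no separate measurement here explains the step.

This single change alters the ring, the heteroatoms and the hydroxy group together, so the compounds shown do not assign the step to any one of these features. Still open, as far as these compounds go, is how this assay would read for a 1,1-dioxothian-4-yl group without the hydroxy, or for an amine or a carboxylic acid at the end of a longer chain at this place.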